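Replacing the pyridin-2-yl group on the amide of compound 1

A few compounds are considered here, and "the series" means these few. Any claim that something is new, unique, unknown or untested is made for them only; others in the source may bear on it.

Among the compounds with values here, compound 1 `O=C(Nc1ccccn1)c1c(O)c2cccnc2n(-c2ccccc2)c1=O` gives -13.5% in a functional assay on the whole organism for inhibition, with Rattus norvegicus as the target, read by paw edema, at a dose of 100 mg/kg by the oral route (on this read-out higher numbers stand for more inhibition at the one dose given (going by the name of the read-out) and lower numbers for less inhibition), the lowest of the three numbers measured so far. Compound 2 `O=C(NCc1ccccc1)c1c(O)c2cccnc2n(-c2ccccc2)c1=O` gives 1.6% and compound 3 `COc1ccc(NC(=O)c2c(O)c3cccnc3n(-c3ccccc3)c2=O)cc1` gives 0.3%. Compound 4 `Cc1cnccc1NC(=O)c1c(O)c2cccnc2n(-c2ccccc2)c1=O` is not yet measured; it differs from compound 1 in a single place: 3-methylpyridin-4-yl in place of pyridin-2-yl on an amide-type nitrogen. Two measured steps also remove the pyridin-2-yl group from the amide-type nitrogen: a number 15.1 percentage points higher from compound 1 to compound 2 (beyond the scatter) and a number 13.8 percentage points higher from compound 1 to compound 3 (beyond the scatter), both modest rises beyond the scatter. Since the change to compound 4 again replaces pyridin-2-yl, a rise of similar size is expected, a number 15.5 percentage points higher from compound 1 to compound 4 (beyond the scatter). Compound 4 is therefore estimated at 2%, with a likely range from -12% to 16%.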

Compound 4, a percentage reported as inhibition, in the whole organism at one dose (the size of the read-out at that dose, not a potency): 26.9%
For compound 4 the middle estimate is 24.9 percentage points below the measured one; measured number above the stated range.
By their numbers in this assay, from the lowest: compound 1; then compounds 3 and 2 (each within the scatter of the next); then compound 4.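

In this assay the group on the amide-type nitrogen can move the number much further than the earlier replacements did: 3-methylpyridin-4-yl gives a number 40.4 percentage points higher from compound 1 to compound 4 (beyond the scatter) in a large step, so these two pyridine groups are not interchangeable. The new group also stands clear of 4-methoxyphenyl and benzyl, with a number 26.6 percentage points higher from compound 3 to compound 4 (beyond the scatter) and a number 25.3 percentage points higher from compound 2 to compound 4 (beyond the scatter) as modest steps. No measurement given here explains the gain. The compounds shown leave open whether the methyl is needed, and plain pyridin-4-yl would test that.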